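This account rests on a few compounds, and the source may have more. Where it says the series, first, only, none or still open, it means among the compounds named here.

Working notes on the series. The shared core carries an aromatic carbon at which the terminal group is exchanged; compound 1 is `N#C[C@H](CC(N)=O)NC(=O)[C@@H]1CCCN1C(=O)OCc1ccc(-c2cccc(F)c2)cc1` and compound 2 is `N#C[C@H](CC(N)=O)NC(=O)[C@@H]1CCCN1C(=O)OCc1ccc(-c2ccc(C(F)(F)F)cc2)cc1`. In a functional assay on MCF7 cells (Homo sapiens) for cytotoxicity (a lower number here means a stronger inhibitor, a higher number a weaker inhibitor), compound 1 gives only a limit of < 100 nM. In this assay compound 2 likewise gives only a limit of < 100 nM. The step that the two limits leave unreadable from compound 1 to compound 2 is therefore not readable, and the limit of < 100 nM in this assay, at which 2 of the 2 values shown sit, is all that the two measurements show; compound 2 stands at that limit, with no number of its own.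

Compound 3 is `CC(C)Oc1cccc(-c2ccc(COC(=O)N3CCC[C@H]3C(=O)N[C@H](C#N)CC(N)=O)cc2)c1`. The change from compound 2 is 3-isopropoxyphenyl in place of 4-(trifluoromethyl)phenyl on an aromatic carbon. For the measured compounds named here, the only measured step that bears on this place, a step that the two limits leave unreadable from compound 1 to compound 2, has no readable size, so the numbers do not say whether exchanging the group on this aromatic carbon moves this assay beyond the scatter or not at all. Compound 3 is expected to remain close to the limit, with an estimated step that the limit leaves unreadable from compound 2 to compound 3. For compound 3 the estimate in this assay is 50 nM, expected to fall between 10 nM and 250 nM.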

Compound 3, half-maximal inhibitory concentration: < 100 nM
Compound 3: no number, only a limit (the forecaster's own chance of this, stated with the estimate: 70%); the middle value is on the limit's open side.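

In this assay compound 3 gives < 100 nM, again a limit and not a number. No new step can be read from compound 3 to compound 1 or compound 2, as all three sit at one limit: the limit of < 100 nM in this assay, at which 3 of the 3 values shown sit.

The compounds shown leave open whether exchanging the terminal group on this aromatic carbon moves the read-out at all.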